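A few compounds are considered here, and "the series" means these few. Any claim that something is new, unique, unknown or untested is made for them only; others in the source may bear on it.

Compound 1 `CC(C)CCn1c(Cn2c(=O)n(C(C)C)c3ccccc32)nc2ccc(C#N)cc21`: 10000 nM
Compound 2 `CC(C)CCn1c(Cn2c(=O)n(C(C)C)c3ccccc32)nc2c(CO)cccc21`: 22000 nM
Compound 3 `CC(C)CCn1c(Cn2c(=O)n(C(C)C)c3ccccc32)nc2c(CCCN)cccc21`: not yet measured

These values come from an ADME assay on HEp-2 cells (Homo sapiens) for cytotoxicity; on this read-out higher numbers stand for lower toxicity in this test and lower numbers for higher toxicity in this test. Of the two measured compounds, compound 2 has the higher number, 22000 nM, and its gap to compound 1 lies beyond the usual scatter.

Compound 3 keeps the shared core and changes one group: 2-aminoethyl in place of hydroxy on a saturated chain carbon bound to an aromatic carbon. Here 2-aminoethyl stands in place of hydroxy on a saturated chain carbon bound to an aromatic carbon, which turns hydroxymethyl into 3-aminopropyl.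

Among the measured compounds shown here, no measured pair shows this change, so the data offer no direct guide to it. In this assay a small downward step is expected, one that stays within the scatter, though this direction is only weakly supported. The expected step is a 1.8-fold lower number from compound 2 to compound 3 (0.26 log units; within the scatter). For compound 3 the estimated value is 12000 nM, with an expected range of 4000 nM to 30000 nM.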

Compound 3, half-maximal cytotoxic concentration: 2340 nM
The estimate for compound 3 lay 5.1-fold (0.71 log units) above the measured number; measured number below the stated range.
By their numbers in this assay, from the lowest: compound 3; then compound 1; then compound 2.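

In this assay, placing 2-aminoethyl in place of hydroxy on a saturated chain carbon bound to an aromatic carbon gives a 9.4-fold lower number from compound 2 to compound 3 (0.97 log units; beyond the scatter), a step beyond the usual scatter. This shows that the position is sensitive to the group it carries: turning hydroxymethyl into 3-aminopropyl goes with higher toxicity in this test, even though the exchanged groups match in their counts of hydrogen-bond donors and acceptors. The available data offer no explanation for this step.

The compounds shown leave open whether the step follows the amine or the longer chain, as the two enter together here. An aminomethyl group or a 3-hydroxypropyl chain at this place would separate them, and a carboxylic acid on the same chain would test a different end group.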